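Methyl removal on the aryl group of compound 2

The compounds below may be only part of what the source reports. "The series", "measured", "known", "first", "only" and "open" are said of these compounds alone.

Measured in a functional assay on A549 cells (Homo sapiens) for cytotoxicity, read by MTT assay, with a stated time of 72 h; a higher number here means a weaker inhibitor, a lower number a stronger inhibitor:
- compound 1 `CNC(=O)c1cc(Oc2ccc(NC(=O)c3cc(-c4ccc(C(F)(F)F)cc4)ncn3)cc2F)ccn1`: > 100000 nM (a limit)
- compound 2 `CNC(=O)c1cc(Oc2ccc(NC(=O)c3cc(-c4ccc(C)cc4)ncn3)cc2F)ccn1`: 13200 nM

Among the measured compounds shown here, compound 2 holds the only actual number so far, as the other result is the limit of > 100000 nM in this assay, at which 1 of the 2 values shown sits. Compound 3 `CNC(=O)c1cc(Oc2ccc(NC(=O)c3cc(-c4ccccc4)ncn3)cc2F)ccn1` has hydrogen in place of methyl on an aromatic carbon, para to a large group: hydrogen in place of methyl on an aromatic carbon. For the measured compounds named here, the only measured step at this place is an at least 7.5-fold lower number from compound 1 to compound 2 (0.87 log units; beyond the scatter), and it replaces trifluoromethyl with methyl. It is a different exchange, and its size is only a bound, so it sets no direction here. No change beyond the scatter is expected in this assay, and the expected step is a 1.1-fold higher number from compound 2 to compound 3 (0.06 log units; within the scatter). Compound 3 is estimated at 15000 nM, with an expected range of 5000 nM to 50000 nM.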

Compound 3, half-maximal inhibitory concentration: 23200 nM
Beside the measured number, compound 3's estimate is 1.5-fold (0.19 log units) below it; measured number inside the range.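

In this assay, hydrogen and methyl on this aromatic carbon are not told apart, with a 1.8-fold higher number from compound 2 to compound 3 (0.24 log units; within the scatter). Trifluoromethyl is so far the only group separated from hydrogen here, with an at least 4.3-fold lower number from compound 1 to compound 3 (0.63 log units; beyond the scatter), and that step is only a bound. Compound 1 stands as a limit and not a number: the limit of > 100000 nM in this assay, at which 1 of the 3 values shown sits.

From the compounds shown here alone, how far compound 1 actually lies from the other two stays open. Also open, going by these compounds, is whether a methoxy group, a chlorine atom or an amine on this carbon would read with hydrogen and methyl or with trifluoromethyl.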